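This account rests on a few compounds, and the source may have more. Where it says the series, first, only, none or still open, it means among the compounds named here.

Compound 3 (`COC(=O)C#CC(CCc1ccccc1)O/C=C/C(=O)OC`) gives 2600 nM in a functional assay on HBL-100 cells (Homo sapiens) for antiproliferative activity, read by sulforhodamine B assay, with a stated time of 48 h (a higher number here means a weaker inhibitor of growth, a lower number a stronger inhibitor of growth), and stands level with its two measured relatives: compound 1 (`CCCCCC(C#CC(=O)OC)O/C=C/C(=O)OC`) gives 1900 nM and compound 2 (`CCCCCCC(C#CC(=O)OC)O/C=C/C(=O)OC`) gives 2500 nM there too. Compound 4 (`COC(=O)C#CC(C)O/C=C/C(=O)OC`) departs from compound 3 in one place (hydrogen in place of benzyl on a saturated chain carbon, two bonds along the chain from an oxygen on an unsaturated carbon and a triple-bonded carbon): hydrogen in place of benzyl on a saturated chain carbon, two bonds along the chain from an oxygen on an unsaturated carbon and a triple-bonded carbon. Within the data shown here, three measured steps bear on this, each altering the same chain. The steps of a 1.3-fold higher number from compound 1 to compound 2 (0.12 log units; within the scatter) and a 1.4-fold higher number from compound 1 to compound 3 (0.14 log units; within the scatter) and also a 1.0-fold higher number from compound 2 to compound 3 (0.02 log units; within the scatter) all stay within the scatter. Among the measured compounds shown here, none of them leaves a chain as short as the one in compound 4, so the data do not fully cover this change. The estimated step (a 1.3-fold higher number from compound 3 to compound 4 (0.13 log units; within the scatter)) therefore stays within the scatter in this assay and leans towards a higher number, with extra room on that side. For compound 4 the estimate is 3500 nM within an expected range of 1500 nM to 10000 nM for now.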

Compound 4, concentration for 50% growth inhibition: 300 nM
Beside the measured number, compound 4's estimate is 12-fold (1.07 log units) above it, outside the stated range (below it).
By their numbers in this assay, from the lowest: compound 4; then compounds 1, 2 and 3 (each within the scatter of the next).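

In this assay the three longer chains stand within the scatter of one another, which made this position look indifferent to what it carries. Replacing those chains with hydrogen shows otherwise: hydrogen in place of benzyl gives a clear drop (an 8.7-fold lower number from compound 3 to compound 4 (0.94 log units; beyond the scatter)), as do hydrogen in place of pentyl (an 8.3-fold lower number from compound 2 to compound 4 (0.92 log units; beyond the scatter)) and hydrogen in place of butyl (a 6.3-fold lower number from compound 1 to compound 4 (0.80 log units; beyond the scatter)), so here the smaller compound 4 is the stronger inhibitor of growth. No measurement shown explains this gain.

Still open, from the compounds shown here alone, is whether the number falls gradually or suddenly as the chain shortens, which a propyl chain on this carbon could help to settle. Also open, going by these compounds, is how an amine or a carboxylic acid on this carbon would compare with hydrogen.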